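The compounds below may be only part of what the source reports. "The series", "measured", "known", "first", "only" and "open" are said of these compounds alone.

Compound 1 `Cc1cccc(-n2nncc2CN2C(=O)C3(C(C#N)=C(N)Oc4c(N)cc5nc6ccccc6nc5c43)c3ccccc32)c1`: in an ADME assay on L02 cells (Homo sapiens) for antiproliferative activity, read by MTT assay, with a stated time of 48 h (a higher number here means a weaker inhibitor, a lower number a stronger inhibitor), compound 1 gives > 50000 nM, which is a limit of the assay.
Compound 2 `N#CC1=C(N)Oc2c(N)cc3nc4ccccc4nc3c2C12C(=O)N(Cc1cnnn1-c1ccc(F)cc1)c1ccccc12`: in this assay compound 2 gives > 50000 nM, again a limit.
For the measured compounds named here, compound 3 `N#CC1=C(N)Oc2c(N)cc3nc4ccccc4nc3c2C12C(=O)N(Cc1cnnn1-c1ccccc1Br)c1ccccc12`: in this assay compound 3 gives 29200 nM, the only number among the three.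

Compound 3 thus stands alone with a read value; the other two sit at the limit of > 50000 nM in this assay, at which 2 of the 3 values shown sit. Compound 4 `CC(=O)Nc1ccc(-n2nncc2CN2C(=O)C3(C(C#N)=C(N)Oc4c(N)cc5nc6ccccc6nc5c43)c3ccccc32)cc1` differs from compound 3 by 4-acetamidophenyl in place of 2-bromophenyl on an aromatic nitrogen. The steps at this position are an at least 1.7-fold lower number from compound 1 to compound 3 (0.23 log units; that floor lies within the scatter) and an at least 1.7-fold lower number from compound 2 to compound 3 (0.23 log units; that floor lies within the scatter), both only floors set by a limit, and a step that the two limits leave unreadable from compound 1 to compound 2. The position has so far moved values only between a limit and a weak number, so for compound 4 no step beyond the scatter is expected in either direction, with a real chance of a limit again. The expected step is a 1.4-fold higher number from compound 3 to compound 4 (0.14 log units; within the scatter). For compound 4 the estimate is 40000 nM, within 15000 nM to 100000 nM.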

Compound 4, half-maximal inhibitory concentration: > 50000 nM
Compound 4 was reported as a limit; the forecaster's own chance of this, stated with the estimate: 55%; at least 1.2-fold (0.09 log units) between middle value and limit.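

For the compounds shown here, the change to 4-acetamidophenyl, the first group here with a hydrogen-bond donor and acceptor, gives an at least 1.7-fold higher number from compound 3 to compound 4 (0.23 log units; that floor lies within the scatter), so only a floor is known. The steps from compound 1 and compound 2 to compound 4 cannot be read, since both ends are limits. The position now has a third group at the limit: the limit of > 50000 nM in this assay, at which 3 of the 4 values shown sit.

On these data alone, whether an amine or a carboxylic acid on this phenyl ring would give a read number stays open. With compound 3 alone read in this assay, the four groups cannot be ranked.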